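Trimethoxyphenyl Variant of a Sulfonyl Amidine Naphthoquinone

The source may hold more compounds than are shown below. What is called first, only, known or untested is meant among the compounds shown, and "the series" means these compounds.

The pair measured so far share one core and differ only in the aryl group on the amine nitrogen. Among the compounds with values here, compound 1 `Cc1ccc(S(=O)(=O)/N=C(/CCNC2=CC(=O)c3ccccc3C2=O)Nc2cccc(C)c2)cc1` gives 9060 nM in a functional assay on HeLa cells (Homo sapiens) for cytotoxicity, read by MTT assay, with a stated time of 48 h (on this read-out lower numbers stand for stronger inhibition and higher numbers for weaker inhibition), whereas compound 2 `COc1ccc(N/C(CCNC2=CC(=O)c3ccccc3C2=O)=N\S(=O)(=O)c2ccc(C)cc2)c(OC)c1` gives 67600 nM, and the one recorded step is a 7.5-fold higher number from compound 1 to compound 2 (0.87 log units; beyond the scatter). Compound 2 therefore stands at the higher of the two numbers, and its nearest neighbour is compound 1.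

Compound 3 `COc1cc(N/C(CCNC2=CC(=O)c3ccccc3C2=O)=N\S(=O)(=O)c2ccc(C)cc2)cc(OC)c1OC` carries the change (3,4,5-trimethoxyphenyl in place of 2,4-dimethoxyphenyl on an amine nitrogen). Within the data shown here, no measured step moves between two methoxy-bearing aryl groups, so the only bearing is indirect: the single step shows that a methoxy-substituted aryl group sat at a markedly higher number than the methyl-substituted one, but nothing shows how a third methoxy group, in the arrangement named, would shift the read-out. Among the measured compounds shown here, with no direct precedent, compound 3 is expected to stay near compound 2, with a 1.1-fold lower number from compound 2 to compound 3 (0.05 log units; within the scatter) estimated as no step beyond the scatter in either direction. The value of compound 3 is accordingly estimated at 60000 nM, with a range from 15000 nM to 250000 nM.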

Compound 3, half-maximal inhibitory concentration: 3390 nM
Compound 3: middle estimate off by 18-fold (1.25 log units), on the high side; measured number outside the range, below it.
By their numbers in this assay, from the lowest: compound 3; then compound 1; then compound 2.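

In this assay, the aryl group on the amine nitrogen proves far more sensitive to its substitution than the first pair could show: with methoxy-bearing aryl groups on both sides, there is a 20-fold lower number from compound 2 to compound 3 (1.30 log units; beyond the scatter). The earlier step alone might have suggested that methoxy groups on this aryl ring raise the number, but the comparison with the methyl-substituted group now runs the other way, with a 2.7-fold lower number from compound 1 to compound 3 (0.43 log units; beyond the scatter), so compound 2 goes one way from compound 1 and compound 3 the other, and the mere presence of methoxy groups does not set the direction. Compound 3 thus holds the lowest number of the three, and nothing available here accounts for this reversal.

The 2,4-dimethoxyphenyl and 3,4,5-trimethoxyphenyl groups differ both in how many methoxy groups they carry and in where these stand, so the compounds shown cannot separate the share of the extra methoxy group from that of the arrangement. From the compounds shown here alone, how an unsubstituted phenyl group, a hydroxyphenyl group or a chlorophenyl group would read at this amine nitrogen also remains open, and with it whether the low number of compound 3 is particular to the trimethoxyphenyl group.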